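Trifluoromethyl for trifluoromethoxy on the aryl of compound 1

A few compounds are considered here, and "the series" means these few. Any claim that something is new, unique, unknown or untested is made for them only; others in the source may bear on it.

Working notes on three measured compounds sharing one core. In a functional assay on HCT-15 cells (Homo sapiens) for cytotoxicity, read by MTT assay, with a stated time of 2 days (a higher number here means a weaker inhibitor, a lower number a stronger inhibitor), compound 1 `Cc1ccc2c(=O)[nH]c(-c3cccc(OC(F)(F)F)c3)nc2c1` gives only a limit, > 50000 nM. Compound 2 `Cc1ccc2c(=O)[nH]c(-c3ccccc3F)nc2c1` gives 10300 nM in this assay. Compound 3 `Cc1ccc2nc(-c3ccccc3N(C)C)[nH]c(=O)c2c1` likewise reaches only a limit in this assay, > 50000 nM. Compound 1 thus stands at the ceiling of the series, since the limit of > 50000 nM in this assay, at which 2 of the 3 values shown sit, describes where most of the shown values sit. Within the data shown here, no step between two measured compounds can be computed here, so nothing measured tells how a change at the aryl moves the read-out.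

Compound 4 `Cc1ccc2c(=O)[nH]c(-c3cccc(C(F)(F)F)c3)nc2c1` is not yet measured. It differs from compound 1 by trifluoromethyl in place of trifluoromethoxy on an aromatic carbon. Among the measured compounds shown here, with no measured step to lean on, the expected movement is none beyond the scatter, or at most a modest gain, giving a step of an at least 1.4-fold lower number from compound 1 to compound 4 (0.15 log units; that floor lies within the scatter). For compound 4 in this assay the estimate is 35000 nM, with a range from 7000 nM to 100000 nM, and a fair chance that only a limit is reported again.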

Compound 4, half-maximal inhibitory concentration: > 50000 nM
Compound 4 ended at the assay's limit (the forecaster's own chance of this, stated with the estimate: 60%); middle value at least 1.4-fold (0.15 log units) from the limit.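

Compound 1 and compound 4 both end at a limit in this assay, so the step between them cannot be read. Both sit at the series ceiling: the limit of > 50000 nM in this assay, at which 3 of the 4 values shown sit.

The compounds shown leave open whether trifluoromethyl in place of trifluoromethoxy on this aromatic carbon changes the cytotoxic read-out at all.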